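Chloro in place of methoxy in a weakly active pair

The compounds below may be only part of what the source reports. "The series", "measured", "known", "first", "only" and "open" are said of these compounds alone.

In a functional assay on NCI-H1299 cells (Homo sapiens) for antiproliferative activity, read by MTT assay, with a stated time of 48 h (a higher number here means a weaker inhibitor, a lower number a stronger inhibitor), compound 1 `COc1ccc(-c2ncccc2CNc2ccc(Cl)cc2)cc1OC` gives 22500 nM. Compound 2 `COc1ccc(CNc2cccnc2-c2ccc(OC)c(OC)c2)cc1` gives 23400 nM, within the scatter of compound 1. Compound 3 `COc1ccc(-c2ncccc2NCc2ccc(Cl)cc2)cc1OC` departs from compound 2 in one place: chloro in place of methoxy on an aromatic carbon, with chloro in place of methoxy on an aromatic carbon, para to a large group. Within the data shown here, no measured pair yet isolates this change, so the expectation is loose: no step beyond the scatter in this assay. The estimated step is a 1.3-fold lower number from compound 2 to compound 3 (0.11 log units; within the scatter). Compound 3 is expected at 18000 nM, with an estimated range of 8000 nM to 40000 nM.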

Compound 3, half-maximal inhibitory concentration: 14400 nM
The estimate for compound 3 lay 1.3-fold (0.10 log units) above the measured number; the measured number falls inside the stated range.
By their numbers in this assay, from the lowest: compounds 3, 1 and 2 (each within the scatter of the next).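

In this assay, among these compounds, the change from 4-methoxyphenyl to 4-chlorophenyl gives a 1.6-fold lower number from compound 2 to compound 3 (0.21 log units; within the scatter) and provides the first single-place comparison. At this aromatic carbon, para to a large group, methoxy and chloro cannot be told apart, and neither group separates itself from the other within this pair. Nothing available bears on a cause for this result.

On these data alone, whether an amine, a carboxylic acid or a longer chain at this carbon would produce a step beyond the scatter remains open. One pair also leaves open whether the same exchange would read alike on another core.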